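Halogenated aryl on the triazole of compound 3

The source may hold more compounds than are shown below. What is called first, only, known or untested is meant among the compounds shown, and "the series" means these compounds.

The measured compounds and their values:
compound 1, `Cc1c(C(=O)Nc2ccc(Oc3ccnc4[nH]ccc34)c(F)c2)nnn1-c1ccccc1`, in a functional assay on HT-29 cells (Homo sapiens) for cytotoxicity, read by MTT assay, with a stated time of 72 h (on this read-out higher numbers stand for weaker inhibition and lower numbers for stronger inhibition), compound 1 gives 290 nM;
compound 2, `Cc1c(C(=O)Nc2ccc(Oc3ccnc4[nH]ccc34)cc2)nnn1-c1ccc(F)c(F)c1`, in this assay compound 2 gives 1070 nM;
compound 3, `O=C(Nc1ccc(Oc2ccnc3[nH]ccc23)c(F)c1)c1nnn(-c2ccccc2)c1C(F)(F)F`, in this assay compound 3 gives 91 nM.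

Compound 3 holds the lowest number of the three in this assay, with compound 1 next and compound 2 furthest away. Within the data shown here, the one single-point step known, a 3.2-fold lower number from compound 1 to compound 3 (0.50 log units; beyond the scatter), concerns the trifluoromethyl group and not the aryl on the triazole nitrogen.

Compound 4, `O=C(Nc1ccc(Oc2ccnc3[nH]ccc23)c(F)c1)c1nnn(-c2ccc(F)c(Cl)c2)c1C(F)(F)F`, differs from compound 3 in that place: 3-chloro-4-fluorophenyl in place of phenyl on an aromatic nitrogen. Among the measured compounds shown here, no measured pair isolates this kind of change. Compound 2 carries a dihalogenated aryl on that nitrogen but also lacks the fluorine on the anilide, so it differs from compound 1 in two places; its values with compound 1 show a higher number for compound 2, without telling which change is responsible.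

The account therefore expects a step of a 1.6-fold higher number from compound 3 to compound 4 (0.22 log units; within the scatter) for compound 4, small and within the scatter. Compound 4 is estimated at 150 nM, in a range from 45 nM to 500 nM.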

Compound 4, half-maximal inhibitory concentration: 630 nM
For compound 4 the middle estimate is 4.2-fold (0.62 log units) below the measured one; measured number outside the range, above it.
By their numbers in this assay, from the lowest: compound 3; then compound 1; then compounds 4 and 2 (each within the scatter of the next).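

In this assay, among these compounds, the aromatic nitrogen does not tolerate every aryl equally: with trifluoromethyl and the anilide fluorine held constant, 3-chloro-4-fluorophenyl in place of phenyl gives a 6.9-fold higher number from compound 3 to compound 4 (0.84 log units; beyond the scatter) as the first clean reading at this position. The earlier compounds shown here could not show this, since compound 2 differs from compound 1 in two places, whereas here the aryl alone changes. No measurement is available that would explain the step.

The compounds shown do not separate the contributions of the chlorine and the fluorine, and a 3-chlorophenyl or a 4-fluorophenyl at this nitrogen would be needed to do so. From the compounds shown here alone, how an amine or a methoxy group on this phenyl would read in this assay also remains open.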